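The source may hold more compounds than are shown below. What is called first, only, known or untested is meant among the compounds shown, and "the series" means these compounds.

In a functional assay on PC-9 cells (Homo sapiens) for inhibition, read by MTT assay, with a stated time of 72 h (on this read-out higher numbers stand for weaker inhibition and lower numbers for stronger inhibition), compound 1 `CCCCCc1c(C)nc2nc(SCc3ccc(Cl)cc3)nn2c1Nc1cc(-c2ccccc2)[nH]n1` gives no number but only the limit of the assay, > 50000 nM. Compound 2 `Cc1cc(Nc2cc(-c3ccccc3)[nH]n2)n2nc(SCc3cccc(Br)c3)nc2n1` gives 8900 nM in this assay, the lowest of the two numbers recorded, while compound 3 `Cc1cc(Nc2ccn(Cc3ccc(F)cc3)n2)n2nc(SCc3ccc(Br)cc3)nc2n1` gives 19400 nM, a higher number than that of compound 2 by more than the usual scatter. Compound 4 `Cc1cc(Nc2cc(-c3ccccc3)[nH]n2)n2nc(SCc3cccc4ccccc34)nc2n1` has not yet been measured in this assay; it differs from compound 2 in one place: naphthalen-1-yl in place of 3-bromophenyl on a saturated chain carbon bound to a sulfur. Among the compounds with values here, no measured pair shows this change, so its size cannot be read from the data; the account expects only a modest step, a 1.1-fold higher number from compound 2 to compound 4 (0.05 log units; within the scatter), with either direction possible. Compound 4 is therefore estimated at 10000 nM in this assay, within a range from 3000 nM to 40000 nM.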

Compound 4, half-maximal inhibitory concentration: 3950 nM
Beside the measured number, compound 4's estimate is 2.5-fold (0.40 log units) above it, within the range that was stated.
By their numbers in this assay, from the lowest: compound 4; then compound 2; then compound 3. At a limit, above all of these: compound 1.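

Setting naphthalen-1-yl in place of 3-bromophenyl on a saturated chain carbon bound to a sulfur gives a 2.3-fold lower number from compound 2 to compound 4 (0.35 log units; beyond the scatter) in this assay and is the first measured step at this place. Bromine is thus not required here, and a group of two six-membered aromatic rings is accepted. Nothing given accounts for the step. The compounds shown leave open whether the lower number comes from the second ring or from the loss of bromine, and how this place would respond to a cyclohexyl group, an amine or a carboxylic acid.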